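The source may hold more compounds than are shown below. What is called first, only, known or untested is meant among the compounds shown, and "the series" means these compounds.

Three compounds share one core and differ only in the aryl group attached to the sulfonyl sulfur. Compound 1 `O=S(=O)(Nc1ccc2oc(-c3ccccc3)nc2c1)c1cccc(C(F)(F)F)c1` carries a trifluoromethyl-bearing phenyl group there. In an assay on cells for inhibition of HSP60/HSP10 (Homo sapiens), with a stated time of 60 min (on this read-out higher numbers stand for weaker inhibition and lower numbers for stronger inhibition), compound 1 gives only a limit, > 100000 nM. Compound 2 `Cc1ccccc1S(=O)(=O)Nc1ccc2oc(-c3ccccc3)nc2c1` carries a methyl-bearing phenyl group. In this assay compound 2 likewise gives only a limit, > 100000 nM. Compound 3 `C=Cc1ccc(S(=O)(=O)Nc2ccc3oc(-c4ccccc4)nc3c2)cc1` carries a 4-vinylphenyl group. In this assay compound 3 also gives only a limit, > 100000 nM. For the measured compounds named here, the one step between two of these that differ in a single place, a step that the two limits leave unreadable from compound 2 to compound 3, cannot be read, and the limit of > 100000 nM in this assay, at which 3 of the 3 values shown sit, describes where all three values stand. Compound 3 therefore sits at the limit, with no number of its own.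

Compound 4 `COc1cccc(S(=O)(=O)Nc2ccc3oc(-c4ccccc4)nc3c2)c1` is the next member of the series. It differs from compound 3 in one place: 3-methoxyphenyl in place of 4-vinylphenyl on a sulfonyl sulfur. Going by the values given here, no measured step of readable size bears on this change; every step among compounds 1, 2 and 3 begins and ends at the limit. Because all three values sit at the limit of > 100000 nM in this assay, at which 3 of the 3 values shown sit, the expectation for compound 4 is that it too will be reported as a limit rather than a number, and the expected step that the limit leaves unreadable from compound 3 to compound 4 is accordingly none that can be read as beyond the scatter. Compound 4 is thus estimated at 150000 nM, within a range from 40000 nM to 600000 nM.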

Compound 4, half-maximal inhibitory concentration: > 100000 nM
Compound 4 gave a limit, no number (the forecaster's own chance of this, stated with the estimate: 85%); the middle value does not contradict the limit.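

For the compounds shown here, no step from compound 1, compound 2 or compound 3 to compound 4 can be read, because each value in this assay is a limit and not a number: the limit of > 100000 nM in this assay, at which 4 of the 4 values shown sit. The compounds shown leave open which group on the sulfonyl sulfur, if any, would give a readable number on this shared core.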